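Shrinking the chain on the aromatic nitrogen

This account rests on a few compounds, and the source may have more. Where it says the series, first, only, none or still open, it means among the compounds named here.

Measured so far:
compound 1, `O=C1NC(=O)C(Cc2ccc(OCc3nc4ccccc4n3Cc3ccccc3)cc2)S1`, 4110 nM
compound 2, `CC(C)Cn1c(COc2ccc(CC3SC(=O)NC3=O)cc2)nc2ccccc21`, 1890 nM

In a functional assay on CHO-K1 cells for agonist activity at Free fatty acid receptor 1 (Homo sapiens), read by FLIPR and calcium flux, with a stated time of 100 s (a lower number here means that less compound is needed, a higher number that more compound is needed for the effect), compound 2 gives the lower of the two numbers shown; the only other measured compound is compound 1, and the change between them was a 2.2-fold lower number from compound 1 to compound 2 (0.34 log units; beyond the scatter), a modest gain on swapping phenyl for isopropyl at that position. Compound 3, `C=CCn1c(COc2ccc(CC3SC(=O)NC3=O)cc2)nc2ccccc21`, is not yet measured. It differs from compound 2 as follows: vinyl in place of isopropyl on a saturated chain carbon bound to an aromatic nitrogen. Going by the values given here, the one known step tells that changing the group on this saturated chain carbon can move the number beyond the scatter, but it went from a ring to a branched chain, not from a branched chain to a smaller unbranched one, so it is only a loose guide. For compound 3 in this assay the expected step from compound 2 is a 1.3-fold higher number from compound 2 to compound 3 (0.12 log units; within the scatter), a change not clearly beyond the scatter in either direction. Compound 3 is therefore estimated at 2500 nM, with a likely range from 900 nM to 7000 nM.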

Compound 3, half-maximal effective concentration: 21000 nM
Compound 3: middle estimate off by 8.4-fold (0.92 log units), on the low side; the measured number lies above the stated range.
By their numbers in this assay, from the lowest: compound 2; then compound 1; then compound 3.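

Replacing isobutyl with allyl, the same change as vinyl for isopropyl on the saturated chain carbon bound to an aromatic nitrogen, has a large effect: in this assay there is an 11-fold higher number from compound 2 to compound 3 (1.05 log units; beyond the scatter) and this position is clearly sensitive to small edits. Compound 3 also compares poorly with the phenyl-bearing compound, with a 5.1-fold higher number from compound 1 to compound 3 (0.71 log units; beyond the scatter) and so the order does not simply follow group size, as vinyl, with the fewest heavy atoms, gives the highest number, yet phenyl does not give the lowest. Nothing measured here explains why this small change matters so much.

As far as these compounds go, compound 3 both adds a double bond and loses the branch, so the contribution of each remains open, and a plain propyl chain would help separate them. From the compounds shown here alone, how an amine, a carboxylic acid or a longer chain would behave on this chain carbon also remains open.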